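Swapping the 2-Chlorophenyl Group for Methoxy

The source may hold more compounds than are shown below. What is called first, only, known or untested is meant among the compounds shown, and "the series" means these compounds.

Compound 1 `CC(C)(C)n1cc2c(n1)C(=O)CC1(CCN(C(=O)c3cc(-c4ccccc4)nc4ccccc34)CC1)O2` gives 1940 nM in a functional assay on A549 cells (Homo sapiens) for inhibition, read by MTT assay, with a stated time of 72 h; a lower number here means a stronger inhibitor, a higher number a weaker inhibitor. Compound 2 `CC(C)(C)n1cc2c(n1)C(=O)CC1(CCN(C(=O)c3cc(-c4ccccc4Cl)nc4ccccc34)CC1)O2` gives 2180 nM in this assay. Compound 3 `CC(C)(C)n1cc2c(n1)C(=O)CC1(CCN(C(=O)c3cc(Cl)nc4ccccc34)CC1)O2` gives 7170 nM in this assay.

Compound 2 stands second highest of the three numbers: compound 1 sits within the scatter of it (a 1.1-fold higher number from compound 1 to compound 2 (0.05 log units; within the scatter)), while compound 3 lies beyond the scatter (a 3.3-fold higher number from compound 2 to compound 3 (0.52 log units; beyond the scatter)).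

The new compound 4 `COc1cc(C(=O)N2CCC3(CC2)CC(=O)c2nn(C(C)(C)C)cc2O3)c2ccccc2n1` changes compound 2 in one place: methoxy in place of 2-chlorophenyl on an aromatic carbon

Two measured steps speak to this. Replacing phenyl with chloro on that aromatic carbon gave a 3.7-fold higher number from compound 1 to compound 3 (0.57 log units; beyond the scatter), and replacing 2-chlorophenyl with chloro gave a 3.3-fold higher number from compound 2 to compound 3 (0.52 log units; beyond the scatter). Both show that taking the aromatic ring away from this carbon and leaving a group without a ring raises the number by a modest amount. Methoxy is likewise a group with no ring, so a modest rise, in the same direction as those two steps, is expected, with the result landing near compound 3.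

The estimate for compound 4 in this assay is therefore 6500 nM, within 2800 nM to 15000 nM, which is expected to mean a step of a 3.0-fold higher number from compound 2 to compound 4 (0.47 log units; beyond the scatter).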

Compound 4, half-maximal inhibitory concentration: > 10000 nM
Compound 4: no number, only a limit (the forecaster's own chance of this, stated with the estimate: 10%); middle value at least 1.5-fold (0.18 log units) from the limit.
By their numbers in this assay, from the lowest: compounds 1 and 2 (each within the scatter of the next); then compound 3. At a limit, above all of these: compound 4.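

In this assay, compound 4 gives only a limit of the assay, not a number: the limit of > 10000 nM in this assay, at which 1 of the 4 values shown sits.

Even so, the size of the change can be bounded, with an at least 4.5-fold higher number from compound 2 to compound 4 (0.66 log units; beyond the scatter) and an at least 5.1-fold higher number from compound 1 to compound 4 (0.71 log units; beyond the scatter), both beyond the scatter, so a second group without a ring on this aromatic carbon, next to the ring nitrogen, also gives a clearly higher number than the two compounds carrying an aromatic ring there. The comparison between the two ring-free groups is less firm, with an at least 1.3-fold higher number from compound 3 to compound 4 (0.14 log units; that floor lies within the scatter), and because that floor lies within the scatter, methoxy cannot yet be separated from chloro.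

From the compounds shown here alone, the true value of compound 4 remains unknown, so how far methoxy falls behind chloro stays open. Also open, going by these compounds, is whether a different small group at this carbon, such as an amine or a longer chain like butoxy, or a different ring, such as a pyridine, would bring the number back towards those of compound 1 and compound 2.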